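Moving the methyl on the phenyl of a TRPV1 antagonist

A few compounds are considered here, and "the series" means these few. Any claim that something is new, unique, unknown or untested is made for them only; others in the source may bear on it.

Compound 1 `O=C1CCc2cccc(Nc3ncc(-c4ccc(C(F)(F)F)cc4)o3)c2C1`: 374 nM
Compound 2 `OC1CCc2cccc(Nc3ncc(-c4ccccc4)o3)c2C1`: 187 nM
Compound 3 `Cc1ccccc1-c1cnc(Nc2cccc3c2CC(O)CC3)o1`: 416 nM

In an in vitro functional assay on cells for antagonist activity at transient receptor potential cation channel subfamily V member 1 (Homo sapiens), read by FLIPR and calcium flux (on this read-out lower numbers stand for stronger inhibition and higher numbers for weaker inhibition), compound 3 gives 416 nM. Among the three measured compounds this is the highest number, but the gap to compound 1 lies within the scatter, so the two cannot be ranked against each other; only compound 2 is clearly apart, and the step of a 2.2-fold higher number from compound 2 to compound 3 (0.35 log units; beyond the scatter) shows that placing a methyl on the phenyl raised the number modestly.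

Compound 4 `Cc1cccc(-c2cnc(Nc3cccc4c3CC(O)CC4)o2)c1` keeps every atom of compound 3 and differs only in where the methyl sits: 3-methylphenyl in place of 2-methylphenyl on an aromatic carbon. Among the measured compounds shown here, no measured step shifts a methyl from one position of the phenyl to another, so the only guidance is that adding the methyl at all was a modest step, as seen from compound 2 to compound 3. Moving it is therefore expected to change the number by no more than that, and plausibly by less than the scatter, in either direction.

Compound 4 is accordingly expected to give 320 nM, within 110 nM to 950 nM, a step of a 1.3-fold lower number from compound 3 to compound 4 (0.11 log units; within the scatter).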

Compound 4, half-maximal inhibitory concentration: 157 nM
For compound 4 the middle estimate is 2.0-fold (0.31 log units) above the measured one, and the stated range covers the measured number.
By their numbers in this assay, from the lowest: compounds 4, 2, 1 and 3 (each within the scatter of the next, the first and the last beyond it).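

In this assay the place of the methyl on the phenyl proves to matter, since 3-methylphenyl in place of 2-methylphenyl gives a 2.6-fold lower number from compound 3 to compound 4 (0.42 log units; beyond the scatter), a step of about the same size as the one that came with adding the methyl as 2-methylphenyl, a 2.2-fold higher number from compound 2 to compound 3 (0.35 log units; beyond the scatter). Adding a methyl is therefore not penalised in itself: as 3-methylphenyl it gives a 1.2-fold lower number from compound 2 to compound 4 (0.08 log units; within the scatter), so the two compounds cannot be told apart and the rise is confined to the 2-methylphenyl compound. Nothing available explains why the two placements differ.

On these data alone, it remains open whether the 3-methylphenyl result is particular to methyl or would also hold for a methoxy group, a chlorine atom or an amine in its place. Whether a longer chain such as ethyl would be tolerated there also remains unsettled.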